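The compounds below may be only part of what the source reports. "The series", "measured", "known", "first", "only" and "open" are said of these compounds alone.

Of the compounds shown here, three built on one shared core have been tested in a functional assay on MDA-MB-231 cells (Homo sapiens) for cytotoxicity, read by MTT assay, with a stated time of 48 h; on this read-out lower numbers stand for stronger inhibition and higher numbers for weaker inhibition. Compound 1 `O=C(/C=C\Nc1ccc2cc[nH]c2c1)c1nc(-c2ccc(C(F)(F)F)cc2)n2ccccc12` gives in this assay > 30000 nM, which is a limit of the assay and not a number. Compound 2 `COc1ccc(N/C=C\C(=O)c2nc(-c3ccc(F)cc3)n3ccccc23)cc1` gives in this assay > 30000 nM, again only a limit. Compound 3 `COc1ccc(N/C=C\C(=O)c2nc(-c3ccc(OC)cc3)n3ccccc23)cc1` gives in this assay > 30000 nM, also a limit. Compound 2 therefore stands at the limit, exactly where the other two values also sit, as the limit of > 30000 nM in this assay, at which 3 of the 3 values shown sit, states. For the measured compounds named here, the single measured step, a step that the two limits leave unreadable from compound 2 to compound 3, has both of its ends at that limit and so shows no readable size.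

Compound 4 `O=C(/C=C\Nc1ccc(Cl)cc1)c1nc(-c2ccc(F)cc2)n2ccccc12` differs from compound 2 by chloro in place of methoxy on an aromatic carbon. Going by the values given here, no measured step touches this change, and the only step available tells nothing. The expectation rests on compound 2 alone, which gives > 30000 nM in this assay, so compound 4 is expected to remain at the limit. The step from compound 2 to compound 4 is expected to be a step that the limit leaves unreadable from compound 2 to compound 4. For compound 4 the estimate is 40000 nM, with a range from 15000 nM to 100000 nM.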

Compound 4, half-maximal inhibitory concentration: 4250 nM
The estimate for compound 4 lay 9.4-fold (0.97 log units) above the measured number; measured number below the stated range.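

Chloro in place of methoxy on an aromatic carbon gives, in this assay, an at least 7.0-fold lower number from compound 2 to compound 4 (0.84 log units; beyond the scatter), so this position can change the read-out, something the earlier compounds could not show. Compound 4 is the only compound shown with a measured number rather than a limit, and the other three all sit at the same limit: the limit of > 30000 nM in this assay, at which 3 of the 4 values shown sit. The value of compound 2 is only a limit, so this step gives a minimum size and the real gap could be larger.

Going by these compounds, how a bromo, a methyl or an amine on that same aromatic carbon would compare with chloro remains open. For the compounds shown here, it is also open whether chloro would bring the same change if the group at the other end of the molecule were different from the one in compound 4.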